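This account rests on a few compounds, and the source may have more. Where it says the series, first, only, none or still open, it means among the compounds named here.

Working notes on the series. In an assay on isolated protein for inhibition of leukotriene B4 receptor 1 (Homo sapiens), tested at 10 uM (a higher number here means more inhibition at the concentration tested (going by the name of the read-out), a lower number less inhibition), compound 1 `CC(=O)c1cc(CO)c(OCCCCCCC#N)cc1O` gives 40%, compound 2 `C=CCc1cc(C(C)=O)c(O)cc1OCCCCCC#N` gives 81%, and compound 3 `C=CCc1cc(C(C)=O)c(O)cc1OCCCCCCC#N` gives 97%. Compound 3 stands highest of the three numbers, with compound 2 nearest and compound 1 furthest, both beyond the scatter. The two steps into compound 3 read a number 57 percentage points higher from compound 1 to compound 3 (beyond the scatter) and a number 16 percentage points higher from compound 2 to compound 3 (beyond the scatter). Compound 4 `C=CCc1cc(C(C)=O)c(O)cc1OCCCCCCCCC#N` is not yet measured; it differs from compound 3 as follows: 2-cyanoethyl in place of cyano on a saturated chain carbon, six bonds along the chain from an oxygen on an aromatic ring. The measured step that bears on this change is a number 16 percentage points higher from compound 2 to compound 3 (beyond the scatter), a modest rise for cyanomethyl in place of cyano on the same chain; the present change carries the nitrile further out along that chain. Compound 3 already sits close to the ceiling of the read-out, so a further rise of that size cannot show. In this assay a step within the scatter is therefore expected, a number 5 percentage points lower from compound 3 to compound 4 (within the scatter). Compound 4 is accordingly estimated at 92%, between 78% and 100%.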

Compound 4, a percentage reported as inhibition, at one concentration (the size of the read-out at that concentration, not a potency): 86%
Estimate against measurement, compound 4: 6 percentage points above, within the range that was stated.
By their numbers in this assay, from the lowest: compound 1; then compounds 2 and 4 (each within the scatter of the next); then compound 3.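

In this assay the rise seen on the first extension of the chain does not continue: 2-cyanoethyl in place of cyano gives a number 11 percentage points lower from compound 3 to compound 4 (beyond the scatter) and so shows that the number at this position can also fall as the nitrile moves further out. Measured from the shorter chain, 3-cyanopropyl in place of cyano gives a number 5 percentage points higher from compound 2 to compound 4 (within the scatter) and so leaves compound 2 and compound 4 not separable, with compound 3 standing out from both among these chain variants. Nothing measured on this series bears on the reason for this turn.

What the compounds shown leave open is whether a longer chain carrying the nitrile would lower the number further. Also open, on these data alone, is whether a carboxylic acid or an amine in place of the nitrile would keep the number seen for compound 3 at 97%.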